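The source may hold more compounds than are shown below. What is called first, only, known or untested is meant among the compounds shown, and "the series" means these compounds.

Measured so far in a functional assay on LNCaP cells (Homo sapiens) for cytotoxicity; a higher number here means a weaker inhibitor, a lower number a stronger inhibitor:

Compound 1 `COc1ccc(Cn2cc(/C=N\NC(=O)c3c[nH]c4ccc(Br)cc34)c3cc(OC)ccc32)cc1` — in this assay compound 1 gives > 100000 nM, which is a limit of the assay and not a number.
Compound 2 `COc1ccc2c(c1)c(/C=N\NC(=O)c1c[nH]c3ccc(Br)cc13)cn2Cc1ccc(Cl)cc1` — compound 2 gives > 100000 nM, again a limit of the assay.
Compound 3 `COc1ccc(Cn2cc(/C=N\NC(=O)c3c[nH]c4ccc(Br)cc34)c3ccc(F)cc32)cc1` — compound 3 gives > 100000 nM, also a limit of the assay.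

Compound 4 `O=C(N/N=C\c1cn(Cc2ccc(Cl)cc2)c2cc(F)ccc12)c1c[nH]c2ccc(Br)cc12` has not yet been measured in this assay. It differs from compound 3 by chloro in place of methoxy on an aromatic carbon. The same change separates compound 1 from compound 2, (chloro in place of methoxy on an aromatic carbon), and there the step that the two limits leave unreadable from compound 1 to compound 2. The cores of compound 1 and compound 3 differ, but that difference is not broken down here. All three measured values sit at the limit (the limit of > 100000 nM in this assay, at which 3 of the 3 values shown sit), so no change in this set has shown a readable size. Compound 4 is therefore expected to sit at the limit too, with an expected step that the limit leaves unreadable from compound 3 to compound 4. The estimate for compound 4 is 200000 nM, between 100000 nM and 1000000 nM.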

Compound 4, half-maximal inhibitory concentration: 24800 nM
Beside the measured number, compound 4's estimate is 8.1-fold (0.91 log units) above it; the whole stated range lies above it.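

In this assay, chloro in place of methoxy gives an at least 4.0-fold lower number from compound 3 to compound 4 (0.60 log units; beyond the scatter), a step read on one core only. The same change from compound 1 to compound 2 cannot be read, since both values are limits of the assay, so the data do not show whether the step carries over to that core or holds only on the core of compound 3. The full size of the step also stays unknown, and most of the set gives no number: the limit of > 100000 nM in this assay, at which 3 of the 4 values shown sit.

The compounds shown leave open how an amine or a carboxylic acid in place of the chloro would read on either core. They also leave open what a longer chain in place of the 4-chlorobenzyl group would do.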